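Fluoromethyl to trifluoromethyl on the saturated ring carbon

A few compounds are considered here, and "the series" means these few. Any claim that something is new, unique, unknown or untested is made for them only; others in the source may bear on it.

Measured in a functional assay (aorta) with Rattus norvegicus as the target; on this read-out higher numbers stand for an effect only at larger amounts of compound and lower numbers for an effect already at smaller amounts:
compound 1, `C/N=C(/S)C1=CC(C)(CF)Oc2ccc([N+](=O)[O-])cc21`, gives 1.62 nM
compound 2, `C/N=C(/S)C1=CC(C)(C(F)(F)F)Oc2ccc([N+](=O)[O-])cc21`, gives 0.302 nM
compound 3, `CC1(CF)C=C(/C(S)=N\CCC#N)c2cc([N+](=O)[O-])ccc2O1`, gives 1.86 nM

Compound 4, `CC1(C(F)(F)F)C=C(/C(S)=N\CCC#N)c2cc([N+](=O)[O-])ccc2O1`, is not yet measured in this assay.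

The change from compound 1 to compound 2 is trifluoromethyl in place of fluoromethyl on a saturated ring carbon and gave a 5.4-fold lower number from compound 1 to compound 2 (0.73 log units; beyond the scatter). The change from compound 3 to compound 4 is trifluoromethyl in place of fluoromethyl on a saturated ring carbon. The two cores differ by cyanomethyl in place of hydrogen on a saturated chain carbon bound to a double-bonded nitrogen, a change that gave a 1.1-fold higher number from compound 1 to compound 3 (0.06 log units; within the scatter). Around the place, the ring atom two ring bonds away bears a group of 4 heavy atoms in compound 1 and a group of 7 heavy atoms in compound 3; the change is therefore the same kind of change, not the same.

Compound 4 is expected to show a step close to the earlier one, a 4.7-fold lower number from compound 3 to compound 4 (0.67 log units; beyond the scatter), resting on compound 1 to compound 2 having given a 5.4-fold lower number from compound 1 to compound 2 (0.73 log units; beyond the scatter) and on compound 3 having given 1.86 nM. Compound 4 is estimated at 0.4 nM, with the range 0.15 nM to 1.1 nM.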

Compound 4, half-maximal effective concentration: 0.363 nM
For compound 4 the middle estimate is 1.1-fold (0.04 log units) above the measured one, and the stated range covers the measured number.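

In this assay, trifluoromethyl in place of fluoromethyl on the saturated ring carbon gave a 5.1-fold lower number from compound 3 to compound 4 (0.71 log units; beyond the scatter), and this step carries from the core of compound 1 to the core of compound 3 without a difference beyond the scatter: the same change on two cores in this assay, a 5.4-fold lower number (0.73 log units; beyond the scatter) from compound 1 to compound 2 and a 5.1-fold lower number (0.71 log units; beyond the scatter) from compound 3 to compound 4, 1.0-fold (0.02 log units) apart, within the scatter of two such steps. Cyanomethyl in place of hydrogen gave a 1.2-fold higher number from compound 2 to compound 4 (0.08 log units; within the scatter), and this step also reads the same on both cores: the same change on two cores in this assay, a 1.1-fold higher number (0.06 log units; within the scatter) from compound 1 to compound 3 and a 1.2-fold higher number (0.08 log units; within the scatter) from compound 2 to compound 4, 1.0-fold (0.02 log units) apart, within the scatter of two such steps. This rests on a single pair of cores in one assay, so it shows no general rule for the series and gives no cause for either step.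

Open, as far as these compounds go, is whether the trifluoromethyl step holds with a longer chain or a carboxylic acid in place of cyanomethyl. Also open, from the compounds shown here alone, is where difluoromethyl would stand on either core.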